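The compounds below may be only part of what the source reports. "The series", "measured", "known", "first", "only" and "open" are said of these compounds alone.

Working notes on the series. The shared core of compound 1 `CC(C)CN(CC(=O)N(CC(C)C)NC(=O)OCc1ccccc1)NC(=O)CBr` gives 6500 nM in a functional assay on L1210 cells (Mus musculus) for inhibition; on this read-out lower numbers stand for stronger inhibition and higher numbers for weaker inhibition. Compound 2 `CC(C)CN(NC(=O)OCc1ccccc1)C(=O)CN(Cc1ccccc1)NC(=O)CBr` gives 1300 nM; the change is phenyl in place of isopropyl on a saturated chain carbon bound to an amine nitrogen, and the step is a 5.0-fold lower number from compound 1 to compound 2 (0.70 log units; beyond the scatter). Compound 3 `CC(C)CN(CC(=O)N(CC(C)C)NC(=O)OCc1ccccc1)/N=C/c1cccc(B(O)O)c1` gives 21200 nM; its core differs from that of compound 1 by a group of 11 heavy atoms (7 carbon, 1 boron, 1 nitrogen, 2 oxygen; one six-membered aromatic ring of carbon only) in place of a group of 5 heavy atoms (2 carbon, 1 nitrogen, 1 oxygen, 1 bromine; no ring), on an amine nitrogen, with the step of a 3.3-fold higher number from compound 1 to compound 3 (0.51 log units; beyond the scatter). Compound 4 `CC(C)CN(CC(=O)N(Cc1ccccc1)NC(=O)OCc1ccccc1)/N=C/c1cccc(B(O)O)c1` is not yet measured; it differs from compound 3 by phenyl in place of isopropyl on a saturated chain carbon bound to an amide-type nitrogen. This is the same kind of change as from compound 1 to compound 2, not the same: there the saturated chain carbon is bound to an amine nitrogen, here to an amide-type nitrogen. The step for compound 4 is expected to be a 2.4-fold lower number from compound 3 to compound 4 (0.37 log units; beyond the scatter), smaller than the earlier one because a 5.0-fold lower number from compound 1 to compound 2 (0.70 log units; beyond the scatter) was recorded at a different place. Compound 4 is thus estimated at 9000 nM, between 3000 nM and 30000 nM.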

Compound 4, half-maximal inhibitory concentration: 16900 nM
Compound 4: the middle estimate sits 1.9-fold (0.27 log units) below what was measured; the range from low to high includes it.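

In this assay, phenyl in place of isopropyl on a saturated chain carbon bound to an amide-type nitrogen gives a 1.3-fold lower number from compound 3 to compound 4 (0.10 log units; within the scatter), so this step shows no measurable change. The size of the step therefore does not carry over from one core to the other in this series, as the two steps set side by side show: the same change on two cores in this assay, a 5.0-fold lower number (0.70 log units; beyond the scatter) from compound 1 to compound 2 and a 1.3-fold lower number (0.10 log units; within the scatter) from compound 3 to compound 4, 4.0-fold (0.60 log units) apart, beyond the scatter of two such steps This does not show whether the difference follows from the core or from the place, as the change sits on an amine nitrogen in one pair and on an amide-type nitrogen in the other, and each case rests on a single pair.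

Open, from the compounds shown here alone, is how the same change reads at each of these two places on the other core. Also open, going by these compounds, is how a longer chain or a carboxylic acid would read at these places.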